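The compounds below may be only part of what the source reports. "The series", "measured", "known", "first", "only" and "open" are said of these compounds alone.

Values measured in a functional assay on the whole organism for inhibition, with Mythimna separata as the target, with a stated time of 5 days; on this read-out lower numbers stand for an effect already at smaller amounts and higher numbers for an effect only at larger amounts of compound:

- Compound 1 `Cc1ccc(-c2nnc(COc3cnn(C(C)(C)C)c(=O)c3Cl)o2)cc1`: 19900 nM
- Compound 2 `Cc1cc(C)cc(-c2nnc(COc3cnn(C(C)(C)C)c(=O)c3Cl)o2)c1`: > 299000 nM, which is a limit and not a true number
- Compound 3 `CC(C)(C)n1ncc(OCc2nnc(-c3ccc(F)cc3)o2)c(Cl)c1=O`: 5200 nM

Compound 3 has the lower of the two true numbers, with compound 1 as its nearest neighbour. The next compound, compound 4 `CC(C)(C)n1ncc(OCc2nnc(-c3ccccc3F)o2)c(Cl)c1=O`, has the same atoms joined differently: 2-fluorophenyl in place of 4-fluorophenyl on an aromatic carbon. The fluorine stays on the phenyl ring, but 2-fluorophenyl now stands in place of 4-fluorophenyl.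

Three measured steps involve changes to this same aryl group. One is a 3.8-fold lower number from compound 1 to compound 3 (0.58 log units; beyond the scatter), a modest step. The two large ones are an at least 15-fold higher number from compound 1 to compound 2 (1.17 log units; beyond the scatter) and an at least 57-fold lower number from compound 2 to compound 3 (1.75 log units; beyond the scatter). Within the data shown here, the number is therefore sensitive to changes here, but no measured compound carries 2-fluorophenyl, so the direction remains uncertain. Among the measured compounds shown here, compound 3 already stands at 5200 nM, the best true number so far, so a rise seems more likely than a further fall. The expected change is a 2.3-fold higher number from compound 3 to compound 4 (0.36 log units; beyond the scatter), a modest step towards a higher number. For compound 4 the estimate is 12000 nM, with an expected range of 2500 nM to 60000 nM.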

Compound 4, half-maximal effective concentration: 16800 nM
Estimate against measurement, compound 4: 1.4-fold (0.15 log units) below; low and high end bracket the measured number.
By their numbers in this assay, from the lowest: compound 3; then compounds 4 and 1 (each within the scatter of the next). At a limit, above all of these: compound 2.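

With the same atoms joined differently, where the fluorine sits on the phenyl ring changes the result in this assay: the change brings a 3.2-fold higher number from compound 3 to compound 4 (0.51 log units; beyond the scatter), so 4-fluorophenyl gives the lower number of the two fluorophenyl groups. The 2-fluorophenyl group does not separate from 4-methylphenyl, with a 1.2-fold lower number from compound 1 to compound 4 (0.07 log units; within the scatter), while replacing 3,5-dimethylphenyl gives an at least 17-fold lower number from compound 2 to compound 4 (1.25 log units; beyond the scatter). Compound 2 stands at a limit and not at a true number, so this last step is only a bound: the limit of > 299000 nM in this assay, at which 1 of the 4 values shown sits.

The compounds shown leave open how a phenyl ring bearing an amine, a methoxy group or a carboxylic acid would behave at this place. They also leave open whether the order of the two fluorophenyl groups would hold with a longer chain in place of the tert-butyl group.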